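Carboxy to (morpholin-4-yl)carbonyl: working notes

The compounds below may be only part of what the source reports. "The series", "measured", "known", "first", "only" and "open" are said of these compounds alone.

Measured in a functional assay on HCT-116 cells (Homo sapiens) for inhibition, read by MTT assay, with a stated time of 72 h; on this read-out higher numbers stand for weaker inhibition of growth and lower numbers for stronger inhibition of growth:
- compound 1 `NNC(=O)COc1ccncc1-c1ccc2ccccc2c1` gives "not determined" (no result reported)
- compound 2 `O=C(O)COc1ccncc1-c1ccc2ccccc2c1` gives "not determined" (no result reported)
- compound 3 `O=C(O)/C=C/c1ccncc1-c1ccc2ccccc2c1` gives > 30000 nM (a limit of the assay, not a number)

Compound 3 therefore stands at a limit (> 30000 nM), and the other two compounds add no number. The whole record in this assay comes down to one reading (the limit of > 30000 nM in this assay, at which 1 of the 3 values shown sits).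

Going from compound 3 to compound 4 `O=C(/C=C/c1ccncc1-c1ccc2ccccc2c1)N1CCOCC1`, morpholin-4-yl takes the place of hydroxy on a carbonyl carbon, which reads as carboxy to (morpholin-4-yl)carbonyl (morpholin-4-yl in place of hydroxy on a carbonyl carbon).

Among the measured compounds shown here, no measured step serves as a guide, so the expectation rests on the limit of compound 3 (> 30000 nM) and on this structural change alone. A modest move toward stronger inhibition of growth is expected, and a result that again reaches the limit would be no surprise. The estimated step, expected to be small and uncertain, reads (an at least 2.5-fold lower number from compound 3 to compound 4 (0.39 log units; beyond the scatter)). The expected value for compound 4 is 12000 nM (estimated range 3000 nM to 40000 nM).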

Compound 4, concentration for 50% growth inhibition: 6040 nM
Compound 4: middle estimate off by 2.0-fold (0.30 log units), on the high side; measured number inside the range.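

In this assay, compound 4 is the only compound shown with a single number, so a change on this carbonyl carbon, whose other neighbour is the double-bonded chain carbon, is now seen to register on this read-out. Morpholin-4-yl in place of hydroxy brings an at least 4.9-fold lower number from compound 3 to compound 4 (0.69 log units; beyond the scatter). Compound 3 gives > 30000 nM, which is a limit and not a number, so the step has no upper size: the limit of > 30000 nM in this assay, at which 1 of the 4 values shown sits.

Open, going by these compounds, is whether this reading belongs to morpholin-4-yl itself or would also come with other replacements of hydroxy, such as a piperidine amide, a dimethylamide or a primary amide on the same carbonyl. Also open, on these data alone, is whether a longer chain carrying the same (morpholin-4-yl)carbonyl would keep this reading.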